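The compounds below may be only part of what the source reports. "The series", "measured", "known", "first", "only" and "open" are said of these compounds alone.

Measured compounds:

compound 1, `COc1c(N2C[C@H]3CCCN(C(=O)Cn4cc(CN5C(=O)/C(=N/O)c6ccccc65)nn4)[C@H]3C2)c(F)cc2c(=O)c(C(=O)O)cn(C3CC3)c12`: 32 ug/mL
compound 2, `COc1c(N2C[C@H]3CCCN(C(=O)Cn4cc(CN5C(=O)/C(=N/O)c6cc(F)ccc65)nn4)[C@H]3C2)c(F)cc2c(=O)c(C(=O)O)cn(C3CC3)c12`: 16 ug/mL
compound 3, `COc1c(N2C[C@H]3CCCN(C(=O)Cn4cc(CN5C(=O)/C(=N/NC(N)=S)c6ccccc65)nn4)[C@H]3C2)c(F)cc2c(=O)c(C(=O)O)cn(C3CC3)c12`: 16 ug/mL

All three share one core and were read in an ADME assay on Vero cells (Chlorocebus sabaeus) for cytotoxicity, read by MTT assay, with a stated time of 72 h; a higher number here means that more compound is tolerated, a lower number that less compound is tolerated. In this assay compound 1 gives 32 ug/mL, compound 2 gives 16 ug/mL and compound 3 gives 16 ug/mL.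

Compound 2 differs from compound 1 by fluoro in place of hydrogen on an aromatic carbon; the step is a 2.0-fold lower number from compound 1 to compound 2 (0.30 log units; within the scatter). Compound 3 differs from compound 1 by a group of 4 heavy atoms (1 carbon, 2 nitrogen, 1 sulfur; no ring) in place of one oxygen atom, on a double-bonded nitrogen; the step is a 2.0-fold lower number from compound 1 to compound 3 (0.30 log units; within the scatter). Within the data shown here, compound 2 and compound 3 stand level at the digits printed; no step between them is broken down here, and both sit with compound 1 inside the usual spread of this assay.

Compound 4, `COc1c(N2C[C@H]3CCCN(C(=O)Cn4cc(CN5C(=O)/C(=N/NC(N)=S)c6cccc(F)c65)nn4)[C@H]3C2)c(F)cc2c(=O)c(C(=O)O)cn(C3CC3)c12`, is not yet measured. It differs from compound 3 by fluoro in place of hydrogen on an aromatic carbon. This is the same kind of change as that from compound 1 to compound 2, but not the same: in compound 2 the fluoro sits meta to a fused ring and para to a fused ring, whereas in compound 4 it sits ortho to a fused ring and meta to a fused ring.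

For compound 4 a step of about a 1.5-fold lower number from compound 3 to compound 4 (0.16 log units; within the scatter) is expected, resting on the small step of a 2.0-fold lower number from compound 1 to compound 2 (0.30 log units; within the scatter) seen for the same kind of change on a different core. Compound 4 is therefore estimated at 11 ug/mL in this assay, with a likely range from 5 ug/mL to 25 ug/mL.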

Compound 4, half-maximal cytotoxic concentration: 8 ug/mL
Estimate against measurement, compound 4: 1.4-fold (0.14 log units) above; measured number inside the range.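

In this assay, the new step is a 2.0-fold lower number from compound 3 to compound 4 (0.30 log units; within the scatter), and set beside the earlier one it reads: the same change on two cores in this assay, a 2.0-fold lower number (0.30 log units; within the scatter) from compound 1 to compound 2 and a 2.0-fold lower number (0.30 log units; within the scatter) from compound 3 to compound 4, 1.0-fold (0.00 log units) apart, within the scatter of two such steps. Within these two cores, then, fluoro in place of hydrogen on an aromatic carbon carries over with no visible difference, but each step lies within the scatter, so neither step on its own establishes a real effect of fluoro on tolerance in these cells. Among these compounds, the agreement also does not show that the change transfers in general: only two cores are covered, and the fluoro of compound 4 sits ortho to a fused ring and meta to a fused ring, a different place from that in compound 2, so core and place change together and cannot be told apart here.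

Open, on these data alone, is how the series reads with the fluoro of compound 2 carried onto the core of compound 3, and the fluoro of compound 4 onto the core of compound 1, pairs that would separate place from core. Also open, as far as these compounds go, is whether a chlorine, a methoxy group or a nitrile on the same aromatic carbon would give steps of similar size in this assay.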